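The source may hold more compounds than are shown below. What is called first, only, known or untested is meant among the compounds shown, and "the series" means these compounds.

Measured in a functional assay on A549 cells (Homo sapiens) for cytotoxicity, read by MTT assay, with a stated time of 72 h; on this read-out lower numbers stand for stronger inhibition and higher numbers for weaker inhibition:

compound 1 `COc1ccc2[nH]c3c(c4c(c5ccnn53)C(=O)NC4=O)c2c1` gives 8000 nM.
compound 2 `Cc1ccc2[nH]c3c(c4c(c5ccnn53)C(=O)NC4=O)c2c1` gives 8000 nM.
compound 3 `COc1ccc2[nH]c(-n3cccn3)cc2c1` gives only a limit of the assay, > 100000 nM.

Compound 1 and compound 2 share a core and differ by methyl in place of methoxy on an aromatic carbon. In this assay this step is no change at the digits printed from compound 1 to compound 2 (within the scatter). Compound 3 carries a different core from compound 1; the difference between the two cores is not broken down here. Compound 3 sits at the limit (the limit of > 100000 nM in this assay, at which 1 of the 3 values shown sits), so its reading is not a number.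

Compound 4 `Cc1ccc2[nH]c(-n3cccn3)cc2c1` is not yet measured. It differs from compound 3 by methyl in place of methoxy on an aromatic carbon. The surroundings are not identical to those of the earlier pair: in compound 3 the ring is part of a fused or bridged system of two rings, in compound 1 of five rings, so this is the same kind of change rather than the same change.

For compound 4 the step of a number no higher from compound 3 to compound 4 (the limit leaves the size open) is expected to be essentially nil, which rests on compound 1 to compound 2 showing no change at the digits printed from compound 1 to compound 2 (within the scatter). Compound 4 is therefore estimated at 100000 nM, most likely again reported only as a limit, between 50000 nM and 300000 nM.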

Compound 4, half-maximal inhibitory concentration: > 100000 nM
Compound 4: a limit, no number (the forecaster's own chance of this, stated with the estimate: 85%); the middle value sits exactly at the limit.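

In this assay, compound 3 and compound 4 both sit at a limit rather than at a number, so no step can be read between them: the limit of > 100000 nM in this assay, at which 2 of the 4 values shown sit.

The compounds shown leave open whether methyl in place of methoxy has any effect on the core of compound 3, and how far past the limit either compound lies.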